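This account rests on a few compounds, and the source may have more. Where it says the series, first, only, none or still open, it means among the compounds named here.

Compound 1 (`O=C(CSc1nncnc1-c1ccccc1Cl)Nc1ccccc1Br`), compound 2 (`O=C(CSc1nncnc1-c1ccccc1Cl)Nc1ccccc1F`) and compound 3 (`O=C(CSc1nncnc1-c1ccccc1Cl)Nc1ccc(Cl)cc1Cl`) share one core and differ in the group on the amide-type nitrogen. In an ADME assay on MT4 cells (Homo sapiens) for cytotoxicity, read by MTT assay (a higher number here means that more compound is tolerated, a lower number that less compound is tolerated), compound 1 gives 73000 nM and compound 2 gives 98000 nM. With only these two numbers available, compound 2 stands level with compound 1, within the usual scatter of the measurement.

Compound 3 has not yet been measured. Going to it from compound 2 means placing 2,4-dichlorophenyl in place of 2-fluorophenyl on an amide-type nitrogen. Among the compounds with values here, only one measured step bears on this change, fluoro in place of bromo on an aromatic carbon, and it is small: a 1.3-fold higher number from compound 1 to compound 2 (0.13 log units; within the scatter). That step exchanges a single halogen, whereas this change replaces the whole group, so the guide is only partial. Within the data shown here, since a 1.3-fold higher number from compound 1 to compound 2 (0.13 log units; within the scatter) is the only evidence, no step clearly beyond the scatter is expected in this assay, and the slight lean towards a lower number is a judgement, not a measured trend. The estimate therefore means an expected 1.4-fold lower number from compound 2 to compound 3 (0.15 log units; within the scatter). For compound 3 the estimated half-maximal cytotoxic concentration is 70000 nM, with an expected range from 30000 nM to 130000 nM.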

Compound 3, half-maximal cytotoxic concentration: 51000 nM
Beside the measured number, compound 3's estimate is 1.4-fold (0.14 log units) above it; measured number inside the range.
By their numbers in this assay, from the lowest: compounds 3, 1 and 2 (each within the scatter of the next).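

In this assay, the change at the amide-type nitrogen now swaps the whole aryl group rather than one halogen for another: 2,4-dichlorophenyl in place of 2-fluorophenyl gives a 1.9-fold lower number from compound 2 to compound 3 (0.28 log units; within the scatter) and 2,4-dichlorophenyl in place of 2-bromophenyl gives a 1.4-fold lower number from compound 1 to compound 3 (0.16 log units; within the scatter) as the second reading of the same kind of change. Neither step clears the scatter, so across compound 1, compound 2 and compound 3 a phenyl carrying two chlorines and a phenyl carrying one halogen cannot be told apart in how much compound the cells tolerate, even though the earlier pair had only shown that one single halogen could stand in for another. No measurement on hand points to what lies behind these numbers.

From the compounds shown here alone, all three groups at this position are halogen-bearing phenyl rings, so it remains open whether an amine, a carboxylic acid or a methoxy group on that ring would give a step beyond the scatter. Going by these compounds, it is equally open whether an unsubstituted phenyl, or a longer alkyl chain in place of the ring, would leave the number where these three compounds stand.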